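A Carbonyl Enters Where a Chlorophenyl Leaves

A few compounds are considered here, and "the series" means these few. Any claim that something is new, unique, unknown or untested is made for them only; others in the source may bear on it.

For the measured compounds named here, compound 1 `O=C(NNc1ccccc1Cl)c1ccc(NS(=O)(=O)c2cnc(O)nc2O)cc1` is the one member of this set with a numerical result: in a functional assay on MDA-MB-231 cells (Homo sapiens) for antiproliferative activity, read by MTT assay, with a stated time of 24 h (on this read-out lower numbers stand for stronger inhibition and higher numbers for weaker inhibition), compound 1 gives 4010 nM. Compound 2 `O=C(NNc1ccccc1F)c1ccccc1NS(=O)(=O)c1cnc(O)nc1O` reaches only a limit of the assay, with compound 2 recorded as > 20000 nM in this assay. Compound 3 `O=C(NNc1ccc(F)cc1)c1ccccc1NS(=O)(=O)c1cnc(O)nc1O` likewise returns a limit, > 20000 nM, in this assay. Going by the values given here, the single step between measured compounds, a step that the two limits leave unreadable from compound 2 to compound 3, is unreadable because both ends sit at the limit of > 20000 nM in this assay, at which 2 of the 3 values shown sit. Compound 4 `O=C(NNC(=O)c1ccc(NS(=O)(=O)c2cnc(O)nc2O)cc1)c1ccc(F)cc1` differs from compound 1 in one place: (4-fluorophenyl)carbonyl in place of 2-chlorophenyl on an amine nitrogen. Among the compounds with values here, no measured step has a carbonyl entering on this nitrogen, so none bears on it directly; what the set does show is that two of three members reach the limit and only compound 1 returns a number. The author therefore expects the step of a 2.0-fold higher number from compound 1 to compound 4 (0.30 log units; within the scatter) to be a loss of moderate size, with a real chance that only a limit is recorded. For compound 4 the expected value in this assay is 8000 nM, between 2000 nM and 30000 nM.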

Compound 4, half-maximal inhibitory concentration: > 20000 nM
Compound 4 was reported as a limit; the forecaster's own chance of this, stated with the estimate: 35%; middle value at least 2.5-fold (0.39 log units) from the limit.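

On this amine nitrogen, replacing 2-chlorophenyl with (4-fluorophenyl)carbonyl gives, in this assay, an at least 4.9-fold higher number from compound 1 to compound 4 (0.69 log units; beyond the scatter). For the compounds shown here, compound 4 is recorded only at a limit, > 20000 nM, so this step fixes the smallest possible size of the loss, which the earlier compounds could not do, since their one step cannot be read. The only numerical result therefore remains isolated, with the rest of the set at one limit: the limit of > 20000 nM in this assay, at which 3 of the 4 values shown sit.

The step changes the carbonyl and the halogen-bearing phenyl together, and the compounds shown do not separate what each contributes or show how large the full loss is. They also leave open whether (2-chlorophenyl)carbonyl or a simple acetyl on this nitrogen would return a number.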